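The source may report more compounds than this note shows. Statements on the series, on what has been measured and on what is new or still open speak of the compounds shown alone.

Measured in a functional assay on A549 cells (Homo sapiens) for cytotoxicity, read by MTT assay, with a stated time of 68 h; a lower number here means a stronger inhibitor, a higher number a weaker inhibitor:
Compound 1 `Cc1ccccc1-c1cccc(NC(=O)C(Cl)Cl)c1`: 9860 nM
Compound 2 `O=C(Nc1cccc(-c2ccsc2)c1)C(Cl)Cl`: > 50000 nM

For the measured compounds named here, compound 1 is the only compound with a numerical value so far. Compound 2 gives > 50000 nM in this assay, and this is a limit of the assay and not a number. Going by the values given here, the series therefore offers no measured step to carry forward.

Compound 3 `O=C(Nc1cccc(-c2cccs2)c1)C(Cl)Cl` has the same atoms as compound 2, joined differently, with thiophen-2-yl in place of thiophen-3-yl on an aromatic carbon. The two groups match in everything counted, so the exchange gives no ground for favouring either direction. The expectation rests on compound 2, whose > 50000 nM is a limit. In this assay, no change beyond the scatter is expected, and compound 3 may again return only a limit. The expected step, an at least 1.4-fold lower number from compound 2 to compound 3 (0.15 log units; that floor lies within the scatter), stays within the scatter. The estimated value for compound 3 is 35000 nM, with an expected range of 10000 nM to 80000 nM.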

Compound 3, half-maximal inhibitory concentration: 47600 nM
The estimate for compound 3 lay 1.4-fold (0.13 log units) below the measured number; the range from low to high includes it.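

For the compounds shown here, with thiophen-2-yl on the aromatic carbon, compound 3 gives 47600 nM in this assay, the first number for a thiophene-bearing member of the series. Compound 2 gives > 50000 nM, which is a limit of the assay and not a number. The exchange of thiophen-3-yl for thiophen-2-yl at this position can therefore be read only as a floor, an at least 1.0-fold lower number from compound 2 to compound 3 (0.02 log units; that floor lies within the scatter), so the pair shows no change beyond the scatter, while the true size of the step stays unknown, and the reading is bounded by a limit: the limit of > 50000 nM in this assay, at which 1 of the 3 values shown sits.

The compounds shown leave open what number compound 2 would give, and so whether the point of attachment on the thiophene matters at all in this assay. They also leave open how the value responds when a group of another kind, such as an amine or a carboxylic acid, stands in place of the thiophen-2-yl on the same aromatic carbon.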